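A few compounds are considered here, and "the series" means these few. Any claim that something is new, unique, unknown or untested is made for them only; others in the source may bear on it.

In a functional assay on MCF7 cells (Homo sapiens) for cytotoxicity, read by MTT assay, with a stated time of 48 h (a lower number here means a stronger inhibitor, a higher number a weaker inhibitor), compound 1 `COc1ccc(/C=C2/S/C(=N/c3ccccc3)N(Cc3ccncc3)C2=O)cc1` gives 31500 nM and compound 2 `O=C1/C(=C\c2ccc(O)c(O)c2)S/C(=N/c2ccccc2)N1Cc1ccncc1` gives 12400 nM while compound 3 `COc1cc(/C=C2/S/C(=N/c3ccccc3)N(Cc3ccncc3)C2=O)ccc1O` gives 28000 nM on the same core. Compound 3 thus shares the upper end of this short range, with a 1.1-fold lower number from compound 1 to compound 3 (0.05 log units; within the scatter) on one side and a 2.3-fold higher number from compound 2 to compound 3 (0.35 log units; beyond the scatter) on the other. Compound 4 `O=C1/C(=C\c2ccccn2)S/C(=N/c2ccccc2)N1Cc1ccncc1` has pyridin-2-yl in place of 4-hydroxy-3-methoxyphenyl on a double-bonded chain carbon bound to a double-bonded ring carbon. The measured steps at this place all exchange one substituted phenyl for another. They stay modest, as a 2.5-fold lower number from compound 1 to compound 2 (0.40 log units; beyond the scatter) shows for the change to 3,4-dihydroxyphenyl, a group that compound 4 does not carry. Going by the values given here, no measured compound has pyridin-2-yl at this place, so the data offer no direct guide to it and the uncertainty is wide. In this assay a step beyond the scatter is therefore not expected in either direction. The estimated step is a 1.1-fold higher number from compound 3 to compound 4 (0.03 log units; within the scatter) and no more can be claimed for it. Compound 4 is estimated at 30000 nM and expected to fall from 13000 nM to 70000 nM on repeated measurement.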

Compound 4, half-maximal inhibitory concentration: 21100 nM
Beside the measured number, compound 4's estimate is 1.4-fold (0.15 log units) above it, and the stated range covers the measured number.
By their numbers in this assay, from the lowest: compounds 2, 4, 3 and 1 (each within the scatter of the next, the first and the last beyond it).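

In this assay, the change from a substituted phenyl to pyridin-2-yl on a double-bonded chain carbon bound to a double-bonded ring carbon gives a 1.3-fold lower number from compound 3 to compound 4 (0.12 log units; within the scatter) and a 1.5-fold lower number from compound 1 to compound 4 (0.17 log units; within the scatter), so this position takes an aromatic ring with a hetero atom, without the hydroxy and methoxy groups, and no step beyond the scatter results from either of these two exchanges. Even measured against the 3,4-dihydroxyphenyl group, the exchange gives a 1.7-fold higher number from compound 2 to compound 4 (0.23 log units; within the scatter), which means that compound 4 cannot be told apart from any of the three earlier compounds, although compound 1 and compound 2 differ from each other beyond the scatter. Nothing available on these compounds offers an explanation for this result.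

The compounds shown leave open how plain phenyl, pyridin-3-yl or pyridin-4-yl would compare at this place, so the part played by the ring nitrogen of pyridin-2-yl cannot be separated from the absence of the other substituents. They also leave open whether an amine, a carboxylic acid or a longer chain on this aromatic ring would give a step beyond the scatter.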